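Fluoro to Methyl: One Small Change, One Assay

A few compounds are considered here, and "the series" means these few. Any claim that something is new, unique, unknown or untested is made for them only; others in the source may bear on it.

Compound 1 `OC[C@]1(c2ccc(F)cc2)NC[C@H](O)[C@H]1O` was tested in an assay on isolated protein for inhibition of alpha-mannosidase (Canavalia ensiformis), tested at 1000 uM (a higher number here means more inhibition at the concentration tested (going by the name of the read-out), a lower number less inhibition), and gives 6.6%. Two related compounds were measured in the same way: compound 3 `C[C@]1(CO)NC[C@@H](O)[C@@H]1O` gives 3.8% and compound 2 `CCCCCCCCC[C@]1(CO)NC[C@@H](O)[C@@H]1O` gives 0%. These three numbers lie within the usual scatter of one another, so none of them stands apart, and all three show little inhibition at the concentration tested. Compound 4 `Cc1ccc([C@@]2(CO)NC[C@H](O)[C@H]2O)cc1` has not yet been measured. It differs from compound 1 in one place: methyl in place of fluoro on an aromatic carbon. Among the measured compounds shown here, no measured pair shows what such a change does here, so the expectation rests only on the small numbers of compound 1, compound 2 and compound 3. The step of a number 1.6 percentage points lower from compound 1 to compound 4 (within the scatter) is expected to be none beyond the scatter. Compound 4 is therefore estimated at 5%, within a range from 0% to 15%.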

Compound 4, a percentage reported as inhibition, at one concentration (the size of the read-out at that concentration, not a potency): 0%
For compound 4 the middle estimate is 5 percentage points above the measured one; the range from low to high includes it.
By their numbers in this assay, from the lowest: compounds 2, 4, 3 and 1 (each within the scatter of the next).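

Among the compounds shown here, this is the first direct reading of methyl in place of fluoro on an aromatic carbon: in this assay the change gives a number 6.6 percentage points lower from compound 1 to compound 4 (within the scatter) for this pair. At this place on the aromatic ring, then, the swap has no effect that can be told from the scatter, and both compounds show little inhibition at the concentration tested. Nothing available explains this result.

Going by these compounds, whether an amine, a carboxylic acid or a longer chain at this place would raise inhibition beyond the scatter remains open. So does whether the fluoro-to-methyl swap would read the same on a more strongly inhibiting compound.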